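Working notes: butyl to benzyl in compound 3

The source may hold more compounds than are shown below. What is called first, only, known or untested is meant among the compounds shown, and "the series" means these compounds.

In a functional assay on FM3A cells (Mus musculus) for inhibition (a higher number here means a weaker inhibitor, a lower number a stronger inhibitor), compound 1 (`CCCCNC(=O)OC/C=C(\C)C1=CC(=O)C(C)(C)O1`) gives 7.7 ug/mL, and compound 2 (`C/C(=C\C=C\c1ccccc1)C1=CC(=O)C(C)(C)O1`) gives 15 ug/mL; these two values lie within the scatter of each other. Compound 3 (`C/C(=C\COC(=O)NCc1ccccc1)C1=CC(=O)C(C)(C)O1`) keeps the core of compound 1 and differs from it as follows: phenyl in place of propyl on a saturated chain carbon bound to an amide-type nitrogen. In short, butyl gives way to benzyl. Within the data shown here, no pair of measured compounds shows this kind of change, so no step beyond the scatter is expected in this assay, in either direction. The expected step of a 1.0-fold higher number from compound 1 to compound 3 (0.02 log units; within the scatter) is estimated to stay within the scatter. For compound 3 the estimated value is 8 ug/mL, with an expected range of 3.5 ug/mL to 18 ug/mL.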

Compound 3, half-maximal inhibitory concentration: 8.1 ug/mL
Beside the measured number, compound 3's estimate is 1.0-fold (0.01 log units) below it, within the range that was stated.
By their numbers in this assay, from the lowest: compounds 1, 3 and 2 (each within the scatter of the next).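

On a saturated chain carbon bound to an amide-type nitrogen, phenyl in place of propyl gives a 1.1-fold higher number from compound 1 to compound 3 (0.02 log units; within the scatter) in this assay. Among these compounds, this is the first single-place comparison, and at this place butyl and benzyl read alike, so an open chain and a six-membered aromatic ring of carbon only are both compatible with inhibition at this level. No measured evidence bears on why the two read alike. Going by these compounds, whether a longer chain, such as octyl, or an amine or a carboxylic acid at this place would also read alike in this assay stays open.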